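Exchanging the dimethylamino for an ethylamino side chain

A few compounds are considered here, and "the series" means these few. Any claim that something is new, unique, unknown or untested is made for them only; others in the source may bear on it.

compound 1 `Cc1nnc(CN(C)C)n1-c1ccc(Cl)cc1C(=O)c1ccccc1` — 0.5 mg/kg
compound 2 `Cc1nnc(CN(C)C)n1-c1ccccc1C(=O)c1ccccc1Cl` — 5 mg/kg
compound 3 `CN(C)Cc1nccn1-c1ccc(Cl)cc1C(=O)c1ccccc1Cl` — 1.2 mg/kg

In a functional assay on the whole organism (strain CF-1) for inhibition, with Mus musculus as the target (on this read-out higher numbers stand for an effect only at larger amounts of compound and lower numbers for an effect already at smaller amounts), compound 1 gives 0.5 mg/kg, the lowest of the three numbers. Compound 3 sits nearest to it, a step beyond the scatter higher, and compound 2 stands furthest, well beyond the scatter. Compound 4 `CCNCc1nnc(C)n1-c1ccc(Cl)cc1C(=O)c1ccccc1` has not yet been measured in this assay. It differs from compound 1 in one place: ethylamino in place of dimethylamino on a saturated chain carbon bound to an aromatic carbon. Going by the values given here, no pair of measured compounds isolates this exchange, so its size is open. A modest step toward higher numbers, or none beyond the scatter, is expected. Compound 4 is estimated at 0.8 mg/kg, with a range from 0.3 mg/kg to 2.5 mg/kg, which means an expected step of a 1.6-fold higher number from compound 1 to compound 4 (0.20 log units; within the scatter).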

Compound 4, dose for half-maximal effect: 0.2 mg/kg
Compound 4: the middle estimate sits 4.0-fold (0.60 log units) above what was measured, and the stated range ends above it.
By their numbers in this assay, from the lowest: compound 4; then compound 1; then compound 3; then compound 2.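

In this assay, ethylamino in place of dimethylamino on a saturated chain carbon bound to an aromatic carbon gives a 2.5-fold lower number from compound 1 to compound 4 (0.40 log units; beyond the scatter) and so moves the number down, not up. The earlier compounds shown here all carried dimethylamino; now a change at this place is seen to matter, though the two groups have the same atoms, joined differently, and ethylamino carries a hydrogen-bond donor that dimethylamino lacks. No measurement available here accounts for the step. Going by these compounds, whether methylamino, a primary amine or propylamino would go lower stays open, as does whether the step carries over to the cores of compound 2 and compound 3.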